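Trifluoromethyl for Trifluoromethoxy on a Spirocyclic Sulfonamide

The source may hold more compounds than are shown below. What is called first, only, known or untested is meant among the compounds shown, and "the series" means these compounds.

Compound 1 `O=C1C=CC2(C=C1)OCC(=O)N2S(=O)(=O)c1ccc(OC(F)(F)F)cc1` carries a trifluoromethoxy group, and in a functional assay on HepG2 cells (Homo sapiens) for inhibition, read by sulforhodamine B assay, with a stated time of 74 h (a higher number here means a weaker inhibitor, a lower number a stronger inhibitor), compound 1 reaches only the limit > 10000 nM. Compound 2 `O=C1C=CC2(C=C1)OCC(=O)N2S(=O)(=O)c1ccccc1OC(F)(F)F` is built from the same atoms joined differently, and the difference between the two cores is not broken down here. In this assay compound 2 also gives only the limit > 10000 nM. Compound 3 `O=C1C=CC2(C=C1)OCC(=O)N2S(=O)(=O)c1ccc(C(F)(F)F)cc1` differs from compound 1 by trifluoromethyl in place of trifluoromethoxy on an aromatic carbon, and in this assay compound 3 gives 750 nM, a step of an at least 13-fold lower number from compound 1 to compound 3 (1.12 log units; beyond the scatter). Compound 4 `O=C1C=CC2(C=C1)OCC(=O)N2S(=O)(=O)c1ccccc1C(F)(F)F` differs from compound 2 by trifluoromethyl in place of trifluoromethoxy on an aromatic carbon, the same kind of change, here ortho to a large group rather than para. A step of similar direction is expected, an at least 2.0-fold lower number from compound 2 to compound 4 (0.30 log units; that floor lies within the scatter), resting on an at least 13-fold lower number from compound 1 to compound 3 (1.12 log units; beyond the scatter), though the start is only (the limit of > 10000 nM in this assay, at which 2 of the 3 values shown sit). Compound 4 is therefore expected to give about 5000 nM, between 1500 nM and 20000 nM.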

Compound 4, half-maximal inhibitory concentration: 590 nM
Estimate against measurement, compound 4: 8.5-fold (0.93 log units) above, outside the stated range (below it).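

In this assay, trifluoromethyl in place of trifluoromethoxy on an aromatic carbon, here ortho to a large group, again gives a large step, an at least 16-fold lower number from compound 2 to compound 4 (1.22 log units; beyond the scatter). The change therefore lowers the number on both cores shown, and the two steps run the same way: the same change on two cores in this assay, an at least 13-fold lower number (1.12 log units; beyond the scatter) from compound 1 to compound 3 and an at least 16-fold lower number (1.22 log units; beyond the scatter) from compound 2 to compound 4; the limit leaves it open whether they differ. The starting points of both steps are limits and not numbers, so the data show the direction of the change but not its true size on either core: the limit of > 10000 nM in this assay, at which 2 of the 4 values shown sit.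

As far as these compounds go, whether the change would carry to any further core remains open. Also open, from the compounds shown here alone, is what an amine, a nitrile or a carboxylic acid would give on the same aromatic carbon.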